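Swapping an Ester for an Alcohol on a Cyclopropane

The source may hold more compounds than are shown below. What is called first, only, known or untested is meant among the compounds shown, and "the series" means these compounds.

Three compounds sharing the same small three-membered carbon ring carrying a trimethoxyphenyl group and an anilide have been tested in a functional assay on A549 cells (Homo sapiens) for cytotoxicity, read by MTT assay, with a stated time of 48 h; on this read-out higher numbers stand for weaker inhibition and lower numbers for stronger inhibition. Compound 1 `CCOC(=O)C1(C(=O)Nc2ccccc2)CC1c1cc(OC)c(OC)c(OC)c1` gives 31500 nM; 48600 nM (2 entries), and compound 3 `CCOC(=O)C1(C(=O)Nc2ccc(F)cc2)CC1c1cc(OC)c(OC)c(OC)c1` gives 22400 nM; 28000 nM (2 entries); the repeats of each, the several entries of compound 1 in this assay, 31500 nM; 48600 nM (2 entries) and (the several entries of compound 3 in this assay, 22400 nM; 28000 nM (2 entries)), fall within the usual scatter. Among the measured compounds shown here, compound 2 `COc1cc([C@H]2C[C@]2(CO)C(=O)Nc2ccccc2Cl)cc(OC)c1OC` gives 36700 nM, which is the only number recorded for it, since two further runs returned no single number. All three compounds therefore sit in the same weak region of this assay, with no ordering among them that the scatter would support.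

Compound 4 `CCOC(=O)[C@]1(C(=O)Nc2ccccc2Cl)C[C@@H]1c1cc(OC)c(OC)c(OC)c1` is compound 2 with one change: ethoxycarbonyl in place of hydroxymethyl on a saturated ring carbon. Compounds 1 and 3 already carry this ethoxycarbonyl group and show numbers close to compound 2, so no step beyond the scatter is expected in either direction. Compound 4 is estimated at 32000 nM, with a range of 12000 nM to 85000 nM, which means an expected step of a 1.1-fold lower number from compound 2 to compound 4 (0.06 log units; within the scatter).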

Compound 4, half-maximal inhibitory concentration: 50900 nM
Estimate against measurement, compound 4: 1.6-fold (0.20 log units) below, and the stated range covers the measured number.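

Until now, hydroxymethyl and ethoxycarbonyl could be set side by side only in compounds that also differed in the anilide. With everything else held fixed, this assay gives a 1.4-fold higher number from compound 2 to compound 4 (0.14 log units; within the scatter). On this saturated ring carbon, replacing hydroxymethyl, which has a hydrogen-bond donor, with the larger ethoxycarbonyl, which has none, therefore leaves the number unmoved beyond the scatter, and the gap is no wider than the one between repeats of a single compound: the several entries of compound 1 in this assay, 31500 nM; 48600 nM (2 entries)

Both groups leave the compounds in the same weak region, so the compounds shown do not reveal how a carboxylic acid or an aminomethyl group on this carbon would read. They also leave open whether the same swap would give a similar step with the fluorine-bearing anilide of compound 3.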